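Series notes: aryl ether end-group variation, maximal response

A few compounds are considered here, and "the series" means these few. Any claim that something is new, unique, unknown or untested is made for them only; others in the source may bear on it.

Of the compounds shown here, two of this set have been measured in an assay on HEK293 cells for positive allosteric modulation of metabotropic glutamate receptor 3 (Rattus norvegicus), read by thallium flux, with a stated time of 2.5 min; a higher number here means a larger maximal response, a lower number a smaller maximal response. Compound 1 `Cc1c(OCCCCOc2ccc(C(=O)O)cc2)ccc(C(=O)CC2CCCC2)c1O` gives 26.7%. Compound 2 `Cc1ccc(C(=O)O)cc1OCCCCOc1ccc(C(=O)CC2CCCC2)c(O)c1C` gives 26.9%. Of the two numbers, compound 2 lies alongside compound 1: the step of a number 0.2 percentage points higher from compound 1 to compound 2 (within the scatter) is within the scatter, so the two cannot be told apart.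

Compound 3 `Cc1c(OCCCCOc2ccc(C(=O)O)c(Cl)c2)ccc(C(=O)CC2CCCC2)c1O` is not yet measured. It differs from compound 2 in a single place: 4-carboxy-3-chlorophenyl in place of 5-carboxy-2-methylphenyl on an oxygen on a saturated carbon.

For the measured compounds named here, the only measured step that bears on this change is the one from compound 1 to compound 2, which also replaces the aryl group on an oxygen on a saturated carbon and gave a number 0.2 percentage points higher from compound 1 to compound 2 (within the scatter), within the scatter. Going by the values given here, nothing so far suggests that exchanging the carboxyphenyl end-group moves the maximal response in this assay. The expected step of a number 0.1 percentage points higher from compound 2 to compound 3 (within the scatter) is therefore none beyond the scatter, in no particular direction. For compound 3 the estimated value in this assay is 27%, with an expected range from 15% to 40%.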

Compound 3, largest response reached (reported as percent of maximum), in percent of the reference or control that the assay uses: 40%
Compound 3: middle estimate off by 13 percentage points, on the low side; low and high end bracket the measured number.
By their numbers in this assay, from the lowest: compounds 1 and 2 (each within the scatter of the next); then compound 3.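

In this assay, the aryl group on an oxygen on a saturated carbon is no longer a silent place in the series: the exchange for 4-carboxy-3-chlorophenyl gives a number 13.1 percentage points higher from compound 2 to compound 3 (beyond the scatter) and so leaves the scatter, which the earlier exchange of end-groups did not. The comparison that isolates the change is chloro in place of hydrogen on an aromatic carbon, with a number 13.3 percentage points higher from compound 1 to compound 3 (beyond the scatter) on an otherwise unchanged structure, so within these compounds the higher maximal response goes with the chlorine and not with exchanging the carboxyphenyl end-group as such. For the compounds shown here, nothing measured so far explains why this substituent raises the response, and the step stands as an observation only.

From the compounds shown here alone, whether fluoro, bromo or methyl in place of the chloro on the same end-group would give a similar step remains open, as does whether chloro would have the same effect on the 5-carboxy-2-methylphenyl end-group. Also open, going by these compounds, is how far the response depends on the carboxylic acid itself, which a tetrazole or a primary amide in its place would test, and on the saturated chain that carries the end-group, which a longer chain would test.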